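This account rests on a few compounds, and the source may have more. Where it says the series, first, only, none or still open, it means among the compounds named here.

Compound 3 `Cc1ccc(C(=O)CCc2nnc(-c3ccccc3Cl)o2)c(C)c1` gives 33.5% in a functional assay on the whole organism (strain Wistar) for inhibition, with Rattus norvegicus as the target, with stated times of 30 min and 2 h, at a dose of 20 mg/kg by the oral route (on this read-out higher numbers stand for more inhibition at the one dose given (going by the name of the read-out) and lower numbers for less inhibition), the lowest of the three numbers measured. Within the data shown here, compound 2 `Cc1ccc(C(=O)CCc2nnc(-c3ccccc3)o2)c(C)c1` gives 36%, and the step of a number 2.5 percentage points lower from compound 2 to compound 3 (within the scatter) is the only measured step that directly frames compound 3. Among the measured compounds shown here, compound 1 `Cc1ccc(C(=O)CCc2nnc(-c3ccc(Cl)cc3)o2)cc1` gives 62.7%; no single step links it to compound 3, but it is the one measured compound bearing the 4-chlorophenyl group. Compound 4 `Cc1ccc(C(=O)CCc2nnc(-c3ccc(Cl)cc3)o2)c(C)c1` differs from compound 3 by 4-chlorophenyl in place of 2-chlorophenyl on an aromatic carbon. Since the chloro-for-hydrogen step was within the scatter, while compound 1 with its 4-chlorophenyl gives 62.7%, a rise of modest size is expected for compound 4, a number 14.5 percentage points higher from compound 3 to compound 4 (beyond the scatter). Compound 4 is therefore estimated at 48%, within 30% to 66%.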

Compound 4, a percentage reported as inhibition, in the whole organism at one dose (the size of the read-out at that dose, not a potency): 53.3%
For compound 4 the middle estimate is 5.3 percentage points below the measured one; measured number inside the range.
By their numbers in this assay, from the lowest: compounds 3 and 2 (each within the scatter of the next); then compounds 4 and 1 (each within the scatter of the next).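

In this assay the swap of 2-chlorophenyl for 4-chlorophenyl gives a number 19.8 percentage points higher from compound 3 to compound 4 (beyond the scatter) and so shows that the place of the chloro on the phenyl ring matters. Chloro in place of hydrogen gives a number 17.3 percentage points higher from compound 2 to compound 4 (beyond the scatter) when it forms 4-chlorophenyl, against a number 2.5 percentage points lower from compound 2 to compound 3 (within the scatter) when it forms 2-chlorophenyl. With 4-chlorophenyl present, methyl in place of hydrogen gives a number 9.4 percentage points lower from compound 1 to compound 4 (within the scatter) and adds no clear change.

Nothing at hand explains these differences. From the compounds shown here alone, whether methoxy, fluoro or an amine in place of the chloro of 4-chlorophenyl would hold the number at this level stays open.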